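The source may hold more compounds than are shown below. What is called first, only, known or untested is meant among the compounds shown, and "the series" means these compounds.

Measured in a functional assay on LOX IMVI cells (Homo sapiens) for inhibition, read by sulforhodamine B assay, with a stated time of 48 h; on this read-out lower numbers stand for stronger inhibition of growth and higher numbers for weaker inhibition of growth:
compound 1, `COc1cc(-c2cc(/C=C/C(=O)c3ccc(N)cc3)[nH]n2)cc(OC)c1OC`, gives 1060 nM.
compound 2, `COc1ccc(C(=O)/C=C/c2cc(-c3cc(OC)c(OC)c(OC)c3)n[nH]2)cc1OC`, gives 1380 nM.
compound 3, `COc1ccc(-c2cc(/C=C/C(=O)c3ccc(N)cc3)[nH]n2)cc1OC`, gives 1920 nM.

All three values sit within the usual scatter of one another, so no order among them is claimed. Compound 2 differs from compound 3 in more than one place; the difference between the two cores is not broken down here. From compound 3 to compound 1 the change is methoxy in place of hydrogen on an aromatic carbon, which made a step of a 1.8-fold lower number from compound 3 to compound 1 (0.26 log units; within the scatter). Compound 4, `COc1cc(C(=O)/C=C/c2cc(-c3cc(OC)c(OC)c(OC)c3)n[nH]2)cc(OC)c1OC`, is not yet measured and is compound 2 with the same change applied: methoxy in place of hydrogen on an aromatic carbon. The two place descriptions match word for word, so this is the same change carried onto a different core. Because the earlier step was a 1.8-fold lower number from compound 3 to compound 1 (0.26 log units; within the scatter) and lay within the scatter, the step from compound 2 to compound 4 is expected to be about a 1.5-fold lower number from compound 2 to compound 4 (0.19 log units; within the scatter) in this assay, in the same direction and likewise small. Compound 4 is accordingly estimated at 900 nM in this assay, with a likely range from 400 nM to 2000 nM.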

Compound 4, concentration for 50% growth inhibition: 1520 nM
Estimate against measurement, compound 4: 1.7-fold (0.23 log units) below, and the stated range covers the measured number.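

Carried onto the second core, methoxy in place of hydrogen on an aromatic carbon makes a 1.1-fold higher number from compound 2 to compound 4 (0.04 log units; within the scatter) in this assay and stays inside the usual scatter, as it did on the first core. Set beside the earlier step, the new one does not differ from it by more than repeated measurement allows: the same change on two cores in this assay, a 1.8-fold lower number (0.26 log units; within the scatter) from compound 3 to compound 1 and a 1.1-fold higher number (0.04 log units; within the scatter) from compound 2 to compound 4, 2.0-fold (0.30 log units) apart, within the scatter of two such steps. Going by these compounds alone, this shows that, across these two cores, the change gives no step that can be told from scatter, but it does not show that methoxy has a real effect on either core, nor that the two cores respond alike in any finer sense, and two pairs support no rule for a third core.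

Open questions concern other groups on that aromatic carbon, such as a chlorine, a hydroxyl, an amine or a carboxylic acid, whose readings cannot be inferred from methoxy and hydrogen. Also open, as far as these compounds go, is whether any replacement there gives a step beyond the scatter on both cores.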